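The compounds below may be only part of what the source reports. "The series", "measured", "known", "first", "only" and "open" are said of these compounds alone.

In a functional assay on KB cells (Homo sapiens) for cytotoxicity (a lower number here means that less compound is needed, a higher number that more compound is needed for the effect), compound 1 `COC1=C(C)C(=O)/C(=C(O)/C=C/c2ccccc2OC)C(=O)C1(C)C` gives 3.3 ug/mL and compound 2 `COC1=C(C)C(=O)/C(=C(O)/C=C/c2ccc(F)cc2)C(=O)C1(C)C` gives 3.7 ug/mL so compound 2 stands level with compound 1 within the scatter. Compound 3 `COC1=C(C)C(=O)/C(=C(O)/C=C/c2ccccc2C)C(=O)C1(C)C` differs from compound 2 by 2-methylphenyl in place of 4-fluorophenyl on a double-bonded chain carbon bound to a double-bonded chain carbon with 2-methylphenyl in place of 4-fluorophenyl on a double-bonded chain carbon bound to a double-bonded chain carbon. For the measured compounds named here, the one measured step at this place is a 1.1-fold higher number from compound 1 to compound 2 (0.05 log units; within the scatter) and it stays within the scatter, so no step beyond the scatter is expected in this assay for this change. The expected step is a 1.1-fold lower number from compound 2 to compound 3 (0.02 log units; within the scatter) and no more than that. Compound 3 is estimated at 3.5 ug/mL with 1.8 ug/mL to 7 ug/mL as the expected range.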

Compound 3, concentration for half-maximal effect: 4.1 ug/mL
Compound 3: middle estimate off by 1.2-fold (0.07 log units), on the low side; the measured number falls inside the stated range.
By their numbers in this assay, from the lowest: compounds 1, 2 and 3 (each within the scatter of the next).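

In this assay, the new compound gives a 1.1-fold higher number from compound 2 to compound 3 (0.04 log units; within the scatter) and, with methyl in place of methoxy on an aromatic carbon, a 1.2-fold higher number from compound 1 to compound 3 (0.09 log units; within the scatter), both within the scatter. The place on a double-bonded chain carbon bound to a double-bonded chain carbon has now taken three substituted phenyl groups, and compound 1, compound 2 and compound 3 stand level. Nothing measured here bears on why these numbers stay level. Open, on these data alone, is whether an amine or a carboxylic acid in place of these phenyl groups would give a step beyond the scatter.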